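Swapping the Aryl Group on an Inactive Series

The compounds below may be only part of what the source reports. "The series", "measured", "known", "first", "only" and "open" are said of these compounds alone.

Compound 3 `O=c1nc2oc(CCCCl)cc2cn1Cc1cn(-c2ccc(Cl)cc2)nn1` carries a 3-chloropropyl group on the shared core and a 4-chlorophenyl group on an aromatic nitrogen. In a functional assay on CFPAC-1 cells (Homo sapiens) for antiproliferative activity, read by MTT assay, with a stated time of 72 h (a lower number here means a stronger inhibitor, a higher number a weaker inhibitor), compound 3 gives > 100000 nM, which is a limit of the assay and not a number. The two other measured compounds tell the same story. Compound 1 `O=c1nc2oc(CCCCl)c(C#CCCCCl)c2cn1Cc1cn(-c2ccc(Cl)cc2)nn1`, which additionally bears a 5-chloropent-1-yn-1-yl group, gives > 100000 nM, again a limit. Compound 2 `O=c1nc2oc(C3CC3)cc2cn1Cc1cn(-c2ccc(Cl)cc2)nn1` has cyclopropyl where compound 3 has 3-chloropropyl; in this assay compound 2 gives > 100000 nM, also a limit. The steps a step that the two limits leave unreadable from compound 1 to compound 3 and a step that the two limits leave unreadable from compound 2 to compound 3 therefore cannot be sized, because every value shown sits at the limit of > 100000 nM in this assay, at which 3 of the 3 values shown sit.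

Compound 4 `O=c1nc2oc(CCCCl)cc2cn1Cc1cn(-c2ccccc2F)nn1` differs from compound 3 only at the aryl group on the aromatic nitrogen: 2-fluorophenyl in place of 4-chlorophenyl on an aromatic nitrogen. Going by the values given here, no measured step touches this part of the molecule, so the only guide is that all three measured compounds are inactive up to the limit, and a change elsewhere gives no reason to expect the series to move into a measurable range. The step that the limit leaves unreadable from compound 3 to compound 4 is thus expected to be none beyond the scatter, most likely leaving compound 4 at the limit as well. Compound 4 is estimated at 150000 nM, within 30000 nM to 1000000 nM.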

Compound 4, half-maximal inhibitory concentration: 81800 nM
Compound 4: middle estimate off by 1.8-fold (0.26 log units), on the high side; low and high end bracket the measured number.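

The aryl group on the aromatic nitrogen is the one place among those shown where a change brings a value inside the measurable range: in this assay compound 4 gives 81800 nM. Compound 3 gives > 100000 nM, which is a limit. The change is an at least 1.2-fold lower number from compound 3 to compound 4 (0.08 log units; that floor lies within the scatter), so the true size of this swap cannot be told apart from scatter on that floor alone, and the series as a whole stays at or close to its ceiling: the limit of > 100000 nM in this assay, at which 3 of the 4 values shown sit.

As far as these compounds go, two things change at once in this swap, the halogen and its place on the ring, so how a 4-fluorophenyl or a 2-chlorophenyl group would read remains open. Also open, from the compounds shown here alone, is whether a plain phenyl, or an aryl group carrying an amine or a carboxylic acid, would bring the number further down, and whether 2-fluorophenyl would give a readable number alongside the cyclopropyl group of compound 2.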